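The source may report more compounds than this note shows. Statements on the series, on what has been measured and on what is new or still open speak of the compounds shown alone.

Of the compounds shown here, three that share one core have been measured in a functional assay on CHO-K1 cells for antagonist activity at prostaglandin E2 receptor EP1 subtype (Homo sapiens), read by FLIPR; a higher number here means a weaker inhibitor, a lower number a stronger inhibitor. Compound 1 `Cc1cc(C(=O)O)nn1Cc1cc(Br)ccc1OCc1ccc(F)cc1F` gives 2.63 nM, and compound 2 `Cc1cc(C(=O)O)nn1Cc1cc(Br)ccc1OCc1ccc(F)cc1` gives 11.8 nM; the step of a 4.5-fold higher number from compound 1 to compound 2 (0.65 log units; beyond the scatter) is modest. Compound 3 `Cc1cc(C(=O)O)nn1Cc1cc(Br)ccc1OCc1cccc([N+](=O)[O-])c1` gives 339 nM, the highest number of the three, standing well apart from both of the others. Compound 4 `Cc1cc(C(=O)O)nn1Cc1cc(Br)ccc1OCc1cc(Cl)cc(Cl)c1` has not been measured yet; it differs from compound 3 in one place: 3,5-dichlorophenyl in place of 3-nitrophenyl on a saturated chain carbon bound to an oxygen on an aromatic ring. Within the data shown here, two measured steps bear on this change, as each of them also exchanges a phenyl carrying only halogens for the 3-nitrophenyl on the same carbon: a 130-fold higher number from compound 1 to compound 3 (2.11 log units; beyond the scatter) and a 29-fold higher number from compound 2 to compound 3 (1.46 log units; beyond the scatter), both large, with the nitro compound in each case giving the much higher number. Among the measured compounds shown here, compound 4 returns to a phenyl that carries only halogens, so the change is expected to run the other way and to lower the number strongly in this assay, though those two steps are the only guide and both earlier partners carried fluorine rather than chlorine. For compound 4 the expected step is a 23-fold lower number from compound 3 to compound 4 (1.35 log units; beyond the scatter). Compound 4 is therefore estimated at 15 nM, with a range from 3 nM to 80 nM.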

Compound 4, inhibition constant: 1120 nM
Estimate against measurement, compound 4: 75-fold (1.87 log units) below; the measured number lies above the stated range.
By their numbers in this assay, from the lowest: compound 1; then compound 2; then compound 3; then compound 4.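

In this assay, a phenyl carrying only halogens on this saturated chain carbon does not by itself give a low number: 3,5-dichlorophenyl gives a 95-fold higher number from compound 2 to compound 4 (1.98 log units; beyond the scatter) and a 430-fold higher number from compound 1 to compound 4 (2.63 log units; beyond the scatter), both large. It even falls behind the 3-nitrophenyl, with a 3.3-fold higher number from compound 3 to compound 4 (0.52 log units; beyond the scatter), a modest step, so the link between halogen-only rings and low numbers seen in compound 1 and compound 2 does not extend to compound 4, which goes against it. Nothing shown here accounts for this reversal.

Compound 4 differs from compound 1 and compound 2 in both the kind of halogen and where the halogens sit on the ring, so these compounds cannot separate the effect of chlorine from the effect of its placement. A phenyl carrying a single chlorine would help to separate the two, while a phenyl carrying a methoxy group would show whether a non-halogen group can give a number as low as those of compound 1 and compound 2.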